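The source may report more compounds than this note shows. Statements on the series, on what has been measured and on what is new or still open speak of the compounds shown alone.

Compound 1 `C=CCOc1nc(N)nc2c1ncn2/C=C1/CC1(CO)CO` gives > 20000 nM in an ADME assay on MOLT-3 cells (Homo sapiens) for cytotoxicity, with a stated time of 7 days (a lower number here means that less compound is tolerated, a higher number that more compound is tolerated), which is a limit of the assay rather than a number.
Compound 2 `Nc1nc(NCc2ccccc2)c2ncn(/C=C3/CC3(CO)CO)c2n1` gives > 20000 nM in this assay, again only a limit.
Compound 3 `CC(C)Sc1nc(N)nc2c1ncn2/C=C1/CC1(CO)CO` gives > 20000 nM in this assay, again only a limit.

All three values sit at the limit of > 20000 nM in this assay, at which 3 of the 3 values shown sit, so compound 2 stands at the limit alongside the other two and cannot be ranked against them. The measured steps say as much: a step that the two limits leave unreadable from compound 1 to compound 2, a step that the two limits leave unreadable from compound 1 to compound 3 and a step that the two limits leave unreadable from compound 2 to compound 3 are each bounded at both ends and yield no size.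

Compound 4 `Nc1nc(SC2CCCC2)c2ncn(/C=C3/CC3(CO)CO)c2n1` differs from compound 2 by cyclopentylsulfanyl in place of benzylamino on an aromatic carbon. Going by the values given here, the measured change that comes closest is the one from compound 2 to compound 3, isopropylsulfanyl in place of benzylamino, which left the value at the limit; the step to compound 4 replaces the same benzylamino with a different alkylsulfanyl group. Among the compounds with values here, no measured step shows a readable direction, so in this assay the expectation is no step beyond the scatter, with the value remaining at the limit. The step from compound 2 to compound 4 is expected to be a step that the limit leaves unreadable from compound 2 to compound 4. Compound 4 is estimated at 30000 nM, with a range of 10000 nM to 100000 nM, and is most likely to be reported only as a limit.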

Compound 4, half-maximal cytotoxic concentration: > 20000 nM
Compound 4 gave a limit, no number; the forecaster's own chance of this, stated with the estimate: 85%; the middle value is on the limit's open side.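

Compound 4 gives > 20000 nM in this assay, again only a limit. Its steps from compound 1, compound 2 and compound 3 cannot be read, as all four compounds stand at the same limit: the limit of > 20000 nM in this assay, at which 4 of the 4 values shown sit. The compounds shown leave open whether any group at this place on the shared core gives a readable value in this assay.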